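The source may hold more compounds than are shown below. What is called first, only, known or untested is meant among the compounds shown, and "the series" means these compounds.

Compound 1 `CC(=O)Nc1ccc(-n2nncc2CN2C(=O)C3(C(C#N)=C(N)Oc4c(N)cc5nc6ccccc6nc5c43)c3ccccc32)cc1` gives > 50000 nM in a functional assay on HCT-116 cells (Homo sapiens) for antiproliferative activity, read by MTT assay, with a stated time of 48 h (on this read-out higher numbers stand for weaker inhibition and lower numbers for stronger inhibition), which is a limit of the assay and not a number.
Compound 2 `CCOc1ccccc1-n1nncc1CN1C(=O)C2(C(C#N)=C(N)Oc3c(N)cc4nc5ccccc5nc4c32)c2ccccc21` gives > 50000 nM in this assay, also a limit.
Compound 3 `N#CC1=C(N)Oc2c(N)cc3nc4ccccc4nc3c2C12C(=O)N(Cc1cnnn1-c1ccc([N+](=O)[O-])cc1)c1ccccc12` gives > 50000 nM in this assay, again a limit.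

Compound 3 thus stands where every measured compound stands, at the limit of > 50000 nM in this assay, at which 3 of the 3 values shown sit. Since each value is a limit, the steps among the three cannot be sized: a step that the two limits leave unreadable from compound 1 to compound 2, a step that the two limits leave unreadable from compound 1 to compound 3 and a step that the two limits leave unreadable from compound 2 to compound 3 all remain unreadable. Each of them changes only the aryl group attached to the ring nitrogen, and each leaves the measurement where it was.

Compound 4 `Cc1ccc(C)c(-n2nncc2CN2C(=O)C3(C(C#N)=C(N)Oc4c(N)cc5nc6ccccc6nc5c43)c3ccccc32)c1` changes the same position: 2,5-dimethylphenyl in place of 4-nitrophenyl on an aromatic nitrogen. All three measured steps bear on this kind of change, and none of them shows any readable movement in this assay. The step from compound 3 to compound 4 is therefore expected to be of no readable size, written as a step that the limit leaves unreadable from compound 3 to compound 4, with no direction that can be justified from the data shown. Compound 4 is accordingly expected to give about 60000 nM in this assay, somewhere between 10000 nM and 300000 nM, and most probably the result will again be reported only as a limit.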

Compound 4, half-maximal inhibitory concentration: > 50000 nM
Compound 4 ended at the assay's limit; the forecaster's own chance of this, stated with the estimate: 75%; the middle value does not contradict the limit.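

Compound 4 gives > 50000 nM in this assay, which is a limit of the assay and not a number, and the steps to it from compound 1, compound 2 and compound 3 cannot be read. The compounds shown leave open whether any of these aryl groups differs from another in strength, and by how much: the limit of > 50000 nM in this assay, at which 4 of the 4 values shown sit.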